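The source may report more compounds than this note shows. Statements on the series, on what has been measured and on what is new or still open speak of the compounds shown alone.

For the measured compounds named here, compound 2 `COCCNC(=C\C(=O)/C=C/c1ccc(O)c(OC)c1)/C=C/c1ccc(O)c(OC)c1` is one of two compounds measured in a toxicity assay on CHO-K1 cells (Cricetulus griseus) for cytotoxicity, read by MTT assay, with a stated time of 48 h (on this read-out lower numbers stand for stronger inhibition and higher numbers for weaker inhibition), where compound 2 gives 63000 nM. The other, compound 1 `COc1cc(/C=C/C(=O)/C=C(/C=C/c2ccc(O)c(OC)c2)NCCO)ccc1O`, in this assay gives 87500 nM. Of the two numbers, that of compound 2 is the lower, but the step of a 1.4-fold lower number from compound 1 to compound 2 (0.14 log units; within the scatter) lies within the scatter, so the two compounds cannot be told apart on this read-out.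

Compound 3 `COCCCNC(=C\C(=O)/C=C/c1ccc(O)c(OC)c1)/C=C/c1ccc(O)c(OC)c1` is the next member of the series. It differs from compound 2 in one place: methoxymethyl in place of methoxy on a saturated chain carbon, two bonds along the chain from an amine nitrogen. Going by the values given here, the only measured step that touches the same chain is a 1.4-fold lower number from compound 1 to compound 2 (0.14 log units; within the scatter), which adds a methyl on the oxygen of that chain and leaves the number within the scatter. The change from compound 2 to compound 3 is of a similar kind, lengthening the chain by methoxymethyl in place of methoxy without adding a donor or acceptor, so the step of a 1.1-fold lower number from compound 2 to compound 3 (0.02 log units; within the scatter) is expected to stay within the scatter. On that basis compound 3 is estimated to give 60000 nM in this assay, with a range from 25000 nM to 140000 nM.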

Compound 3, half-maximal inhibitory concentration in the CHO-K1 assay: 53700 nM
Beside the measured number, compound 3's estimate is 1.1-fold (0.05 log units) above it; the range from low to high includes it.
By their numbers in the CHO-K1 assay, from the lowest: compounds 3, 2 and 1 (each within the scatter of the next).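

In the CHO-K1 assay the chain can be lengthened without a readable shift: going from 2-methoxyethyl to 3-methoxypropyl gives a 1.2-fold lower number from compound 2 to compound 3 (0.07 log units; within the scatter), and methoxymethyl in place of hydroxy gives a 1.6-fold lower number from compound 1 to compound 3 (0.21 log units; within the scatter), so the three compounds still cannot be told apart on this read-out. For the compounds shown here, what the earlier compounds did not show is a second read-out at this position: in a physicochemical assay for solubility, using the shake flask method, in phosphate buffer, with a stated time of 90 min, at pH 6.8 (on this read-out higher numbers stand for higher solubility and lower numbers for lower solubility), compound 2 gives 16700 nM and compound 3 gives 7700 nM. The change from 2-methoxyethyl to 3-methoxypropyl, which cannot be read in the CHO-K1 assay, therefore does appear in the physicochemical assay as a modest loss of solubility: the measured solubility of compound 2, 16700 nM, and of compound 3, 7700 nM, a 2.2-fold lower number (0.34 log units; beyond the scatter)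

Going by these compounds, it remains open whether a longer chain, an amine or a carboxylic acid in place of methoxymethyl at this position would move the number in the CHO-K1 assay beyond the scatter. On these data alone, it is also open whether further lengthening would continue the fall in the physicochemical assay, as a single step sets no trend.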